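Naphthalen-1-yl for thiophen-2-yl at the acetal-type carbon

The source may report more compounds than this note shows. Statements on the series, on what has been measured and on what is new or still open speak of the compounds shown alone.

Compound 2 `O=C(O)CC/C=C\CC1COC(c2cccs2)OC1c1cccnc1` gives 71 nM in an assay for inhibition of Thromboxane-A synthase (Homo sapiens), using microsomes; on this read-out higher numbers stand for weaker inhibition and lower numbers for stronger inhibition. For the measured compounds named here, the only other measured member, compound 1 `O=C(O)CC/C=C\CC1COC(c2ccc(Cl)cc2Cl)OC1c1cccnc1`, gives 42 nM in this assay, and the step of a 1.7-fold higher number from compound 1 to compound 2 (0.23 log units; within the scatter) places the two together within the usual scatter, so no ranking between compound 2 and compound 1 is supported. Compound 3 `O=C(O)CC/C=C\CC1COC(c2cccc3ccccc23)OC1c1cccnc1` differs from compound 2 by the change (naphthalen-1-yl in place of thiophen-2-yl on a saturated ring carbon). Going by the values given here, the single step that bears on this position, a 1.7-fold higher number from compound 1 to compound 2 (0.23 log units; within the scatter), exchanged one aryl group for another at the same saturated ring carbon without moving the number beyond the scatter. On that basis no step beyond the scatter is expected for compound 3, though the entering group is larger than either earlier group, which widens the range. Compound 3 is expected at about 60 nM, between 20 nM and 200 nM, implying a step of a 1.2-fold lower number from compound 2 to compound 3 (0.07 log units; within the scatter).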

Compound 3, half-maximal inhibitory concentration: 40 nM
For compound 3 the middle estimate is 1.5-fold (0.18 log units) above the measured one, and the stated range covers the measured number.
By their numbers in this assay, from the lowest: compounds 3, 1 and 2 (each within the scatter of the next).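

At the saturated ring carbon between two ring oxygen atoms, the three aryl groups are not separated in this assay: a 1.8-fold lower number from compound 2 to compound 3 (0.25 log units; within the scatter) and a 1.1-fold lower number from compound 1 to compound 3 (0.02 log units; within the scatter) both lie within the scatter. This position therefore accepts naphthalen-1-yl, with 10 heavy atoms in 2 six-membered aromatic rings of carbon only and 0 hydrogen-bond acceptors, in place of thiophen-2-yl, with 5 heavy atoms and 1 hydrogen-bond acceptor, without a step beyond the scatter, a wider change than the earlier pair covered. Nothing measured alongside these values speaks to why the numbers stay together.

From the compounds shown here alone, all three groups at this carbon are aromatic rings, so it remains open whether a saturated cyclohexyl ring, an amine or a carboxylic acid there would also stay within the scatter. Going by these compounds, a longer chain in place of the 5-carboxypent-2-en-1-yl group also remains open.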